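This account rests on a few compounds, and the source may have more. Where it says the series, first, only, none or still open, it means among the compounds named here.

Working notes on the series. Compound 1 `O=S(=O)(Nc1ccc2oc(-c3ccccc3)nc2c1)c1cccc(C(F)(F)F)c1` is measured only to the limit of the assay: in an assay on cells for inhibition of HSP60/HSP10 (Homo sapiens), with a stated time of 60 min (on this read-out higher numbers stand for weaker inhibition and lower numbers for stronger inhibition), compound 1 gives > 100000 nM, which is the limit of > 100000 nM in this assay, at which 1 of the 3 values shown sits. Compound 2 `O=S(=O)(Nc1ccc(-c2nc3ccccc3o2)cc1)c1ccc(Cl)c(C(F)(F)F)c1` gives 12000 nM in this assay and stands lowest of the two numbers shown. Compound 3 `O=S(=O)(Nc1ccc(-c2nc3ccccc3o2)cc1)c1ccc(F)c(C(F)(F)F)c1` gives 28000 nM in this assay. Going by the values given here, the one step between two numbers, a 2.3-fold higher number from compound 2 to compound 3 (0.37 log units; beyond the scatter), is the only measured guide to how a change on the sulfonyl-bearing ring moves the read-out, and it is modest.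

Compound 4 `O=[N+]([O-])c1cc(S(=O)(=O)Nc2ccc(-c3nc4ccccc4o3)cc2)ccc1Cl` has not been measured. Against compound 2 the change is nitro in place of trifluoromethyl on an aromatic carbon. Among the compounds with values here, no measured step exchanges trifluoromethyl for nitro, so the direction is open; the measured step on the same ring suggests the size of a single substituent change here is modest. Compound 4 is expected to give 15000 nM in this assay, with a range from 5000 nM to 50000 nM. The step expected is a 1.3-fold higher number from compound 2 to compound 4 (0.10 log units; within the scatter), which may lie within the scatter in either direction.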

Compound 4, half-maximal inhibitory concentration: 17000 nM
Compound 4: the middle estimate sits 1.1-fold (0.05 log units) below what was measured; the measured number falls inside the stated range.
By their numbers in this assay, from the lowest: compounds 2, 4 and 3 (each within the scatter of the next, the first and the last beyond it). At a limit, above all of these: compound 1.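

Going by these compounds alone, the earlier compounds varied only the halogen on this ring; here the group ortho to a chloro group is exchanged for the first time. In this assay the exchange gives a 1.4-fold higher number from compound 2 to compound 4 (0.15 log units; within the scatter) and so does not separate nitro from trifluoromethyl at this position, even though the entering group has two hydrogen-bond acceptors and the leaving group has none. Nothing given here accounts for the size of this step.

What the compounds shown leave open is whether this position responds at all to groups of another kind, such as an amine, a carboxylic acid or a longer chain, since nitro and trifluoromethyl are the only two shown there. As far as these compounds go, compound 2 gives 12000 nM, and equally open is whether any exchange at this position can bring the number clearly lower.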